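A few compounds are considered here, and "the series" means these few. Any claim that something is new, unique, unknown or untested is made for them only; others in the source may bear on it.

In a functional assay on L02 cells (Homo sapiens) for inhibition, read by Griess assay, with stated times of 1 h and 24 h (a higher number here means a weaker inhibitor, a lower number a stronger inhibitor), compound 1 `CNc1nc(/C=C/c2ccco2)nc2ccsc12` gives 811000 nM. Going by these compounds, compound 2 `CN1CCN(c2nc(/C=C/c3ccco3)nc3ccsc23)CC1` has only a limit of the assay, > 1000000 nM, so its true position is unknown. For the measured compounds named here, the sole measured step, an at least 1.2-fold higher number from compound 1 to compound 2 (0.09 log units; that floor lies within the scatter), therefore sets no firm size. Compound 3 `C(=C/c1ccco1)\c1nc(NCc2ccccc2)c2sccc2n1` follows from compound 2 by benzylamino in place of 4-methylpiperazin-1-yl on an aromatic carbon, with benzylamino in place of 4-methylpiperazin-1-yl on an aromatic carbon. The nearest guide is compound 1 at 811000 nM, which also carries a secondary amino group there, so a modest move to a lower number is expected. Another limit of the assay remains possible for compound 3. The expected step is an at least 2.5-fold lower number from compound 2 to compound 3 (0.39 log units; beyond the scatter). For compound 3 the estimated value is 400000 nM, with an expected range of 100000 nM to 1000000 nM.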

Compound 3, half-maximal inhibitory concentration: > 1000000 nM
Compound 3 was reported as a limit; the forecaster's own chance of this, stated with the estimate: 20%; middle value at least 2.5-fold (0.39 log units) from the limit.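

In this assay compound 3, with benzylamino at this position, gives only a limit of the assay, > 1000000 nM. Phenyl in place of hydrogen on the saturated chain carbon gives an at least 1.2-fold higher number from compound 1 to compound 3 (0.09 log units; that floor lies within the scatter), which sets a floor and no firm size. The step between the two limits cannot be read, and a secondary amino group at this position does not guarantee a value inside the assay's range: the limit of > 1000000 nM in this assay, at which 2 of the 3 values shown sit.

Going by these compounds, it remains open whether any group here gives a clearly lower number than compound 1. An unsubstituted amino group or a morpholin-4-yl group would test this position further.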